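The source may report more compounds than this note shows. Statements on the series, on what has been measured and on what is new or still open speak of the compounds shown alone.

In a functional assay on THP-1 cells (Homo sapiens) for cytotoxicity, read by MTT assay, with a stated time of 24 h (on this read-out higher numbers stand for weaker inhibition and lower numbers for stronger inhibition), two compounds built on a shared core, compound 1 `CCCCCCCCCCn1cc(-c2nc3ccccc3cc2CCCC)nn1` and compound 2 `CCCCCCCCCCn1cc(-c2nc3ccccc3cc2CCC)nn1`, were tested. Compound 1 gives only a limit of the assay, > 100 ug/mL. Compound 2 likewise gives only a limit of the assay, > 100 ug/mL. Between these two stands a single change, (methyl in place of hydrogen on a saturated chain carbon, three bonds along the chain from an aromatic carbon), and the step it made is a step that the two limits leave unreadable from compound 2 to compound 1. Compound 3 `CCCc1cc2ccccc2nc1-c1cn(CCC(F)(F)C(F)(F)C(F)(F)C(F)(F)C(F)(F)C(F)(F)C(F)(F)C(F)(F)F)nn1` rests on a different core; how its core differs from that of compound 2 is not broken down here. In this assay compound 3 also gives only a limit of the assay, > 100 ug/mL. Compound 4 `CCCCc1cc2ccccc2nc1-c1cn(CCC(F)(F)C(F)(F)C(F)(F)C(F)(F)C(F)(F)C(F)(F)C(F)(F)C(F)(F)F)nn1` has not yet been measured and differs from compound 3 by the same change, (methyl in place of hydrogen on a saturated chain carbon, three bonds along the chain from an aromatic carbon), at the same place. Because every value shown so far sits at the limit of > 100 ug/mL in this assay, at which 3 of the 3 values shown sit, and the earlier step that the two limits leave unreadable from compound 2 to compound 1 could not be read, the step from compound 3 to compound 4 is expected to be a step that the limit leaves unreadable from compound 3 to compound 4 and is likewise unlikely to be readable. Compound 4 is therefore estimated at 150 ug/mL, most probably reported again only as a limit, with a plausible spread from 80 ug/mL to 400 ug/mL.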

Compound 4, half-maximal inhibitory concentration: > 100 ug/mL
Compound 4 gave a limit, no number (the forecaster's own chance of this, stated with the estimate: 85%); the middle value lies beyond the limit too.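

Compound 3 and compound 4 each give only a limit of the assay in this assay, so no size can be read for the step between them, and the same holds for all the compounds shown: the limit of > 100 ug/mL in this assay, at which 4 of the 4 values shown sit.

The compounds shown leave open whether the change from propyl to butyl has any effect at all in this assay.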